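Swapping the aryl hydrazone unit on a thiosemicarbazide

The source may hold more compounds than are shown below. What is called first, only, known or untested is meant among the compounds shown, and "the series" means these compounds.

Compound 1 `CC1=CC[C@@H]([C@@](C)(O)CCCC(C)(C)NC(=S)NN)CC1` carries a thiosemicarbazide chain on a monoterpene-derived core. In a functional assay on K562 cells (Homo sapiens) for cytotoxicity, read by sulforhodamine B assay (on this read-out higher numbers stand for lower toxicity in this test and lower numbers for higher toxicity in this test), compound 1 gives 9580 nM. Compound 2 `CC1=CC[C@@H]([C@@](C)(O)CCCC(C)(C)NC(=S)N/N=C\c2ccc(Cl)cc2)CC1` extends that chain into an aryl hydrazone; in this assay compound 2 gives 10300 nM. The step of a 1.1-fold higher number from compound 1 to compound 2 (0.03 log units; within the scatter) shows that attaching the aromatic unit left the number where it was. Among the compounds with values here, of the two compounds measured so far, compound 2 and compound 1 therefore cannot be told apart in this assay, and neither can be called the more or the less toxic one.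

Compound 3 `CC1=CC[C@@H]([C@@](C)(O)CCCC(C)(C)NC(=S)N/N=C(/C)c2ccccc2)CC1` keeps the whole shared core and changes only the aryl hydrazone end: a group of 9 heavy atoms (8 carbon, 1 nitrogen; one six-membered aromatic ring of carbon only) in place of a group of 9 heavy atoms (7 carbon, 1 nitrogen, 1 chlorine; one six-membered aromatic ring of carbon only), on an amide-type nitrogen. Within the data shown here, the only measured step that bears on this region, from compound 1 to compound 2, lay within the scatter, and the new group is of the same size and the same shape class as the one it replaces. Nothing in the numbers points to a change in either direction, so compound 3 is expected to show a 1.0-fold lower number from compound 2 to compound 3 (0.01 log units; within the scatter). The estimate for compound 3 in this assay is 10000 nM, with a range from 4000 nM to 25000 nM.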

Compound 3, concentration lethal to 50% of the cells: 1540 nM
The estimate for compound 3 lay 6.5-fold (0.81 log units) above the measured number; measured number below the stated range.
By their numbers in this assay, from the lowest: compound 3; then compounds 1 and 2 (each within the scatter of the next).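

This position on the amide-type nitrogen turns out not to be indifferent to what it carries: the two groups match in heavy-atom count, aromatic ring, double bond and hydrogen-bond counts, yet this assay shows a 6.7-fold lower number from compound 2 to compound 3 (0.83 log units; beyond the scatter), towards higher toxicity in this test. The earlier picture, in which adding an aromatic unit to the thiosemicarbazide left the number in place, therefore holds only for the chlorine-bearing group of compound 2, since the group without chlorine gives a 6.2-fold lower number from compound 1 to compound 3 (0.79 log units; beyond the scatter), so compound 3 stands apart from both other compounds. Nothing measured here gives a reason for this drop.

The group that enters differs from the one that leaves in two ways at once, having lost the chlorine and gained a carbon, and these three compounds cannot show which of the two differences carries the step. Also open, from the compounds shown here alone, is how the number would respond to a hydrazone unit with bromine in place of chlorine, or to one carrying an amine or a carboxylic acid, and whether the shift seen here would then grow, shrink or vanish.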